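Chloro for Methyl on the Carbonyl-Bearing Ring

The source may hold more compounds than are shown below. What is called first, only, known or untested is meant among the compounds shown, and "the series" means these compounds.

Measured compounds:
compound 1, `O=C(NCc1ccc(CNS(=O)(=O)c2ccccc2)cc1)c1cccc(F)c1`: 100 nM
compound 2, `Cc1ccccc1C(=O)NCc1ccc(CNS(=O)(=O)c2ccccc2)cc1`: 1 nM

Both compounds share a core and differ only in the ring attached to the carbonyl carbon. In an assay on MDA-MB-231 cells for binding affinity to C-X-C chemokine receptor type 4 (Homo sapiens), read by immunofluorescence and microscopy, with stated times of 10 min and 30 min (on this read-out lower numbers stand for an effect already at smaller amounts and higher numbers for an effect only at larger amounts of compound), compound 1 gives 100 nM. Within the data shown here, compound 2 gives 1 nM and is the lowest of the two numbers; its only neighbour is compound 1, separated by a 100-fold lower number from compound 1 to compound 2 (2.00 log units; beyond the scatter), a change that swaps 2-methylphenyl for 3-fluorophenyl on the carbonyl carbon.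

Compound 3, `O=C(NCc1ccc(CNS(=O)(=O)c2ccccc2)cc1)c1ccccc1Cl`, keeps everything of compound 2 except one group: chloro in place of methyl on an aromatic carbon. Among the measured compounds shown here, no measured pair shows this exact swap, so the one step available is only an indirect guide. It shows that this ring tolerates a small group at the 2-position very well, but it says nothing about chloro against methyl. The expected step is therefore a modest one, a 3.0-fold higher number from compound 2 to compound 3 (0.48 log units; beyond the scatter), with room in either direction. Compound 3 is estimated at 3 nM, within a range from 0.5 nM to 30 nM in this assay.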

Compound 3, effective concentration (reported as EC, without a stated level of effect): 10 nM
For compound 3 the middle estimate is 3.3-fold (0.52 log units) below the measured one; the range from low to high includes it.
By their numbers in this assay, from the lowest: compound 2; then compound 3; then compound 1.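

In this assay the change from methyl to chloro gives a 10-fold higher number from compound 2 to compound 3 (1.00 log units; beyond the scatter) and so shows that this position tells apart two groups that look alike by simple counts: each has one heavy atom, no hydrogen-bond donors or acceptors and no net charge. Compound 3 still keeps part of the gain seen with compound 2, since the other new comparison gives a 10-fold lower number from compound 1 to compound 3 (1.00 log units; beyond the scatter) and both groups with a substituent in the 2-position therefore give lower numbers than the 3-fluorophenyl group, although that comparison changes the atom and its place together. The data offer no measured explanation for the gap between methyl and chloro.

The compounds shown leave open how far this trend reaches, since only methyl and chloro appear in the 2-position and a 2-methoxyphenyl, 2-aminophenyl or plain phenyl group would show whether methyl is unusual there or simply one of several groups that give low numbers. A 2-fluorophenyl group would also help, as it would separate the effect of the fluorine atom from that of its place on the ring.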